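A few compounds are considered here, and "the series" means these few. Any claim that something is new, unique, unknown or untested is made for them only; others in the source may bear on it.

In an ADME assay on J774.1 cells (Mus musculus) for cytotoxicity, read by MTT assay, with a stated time of 48 h (on this read-out higher numbers stand for weaker inhibition and lower numbers for stronger inhibition), compound 2 `CC(=O)Nc1ccc(/C=N/NC(=O)c2no[n+]([O-])c2C)cc1` gives 235000 nM, within the scatter of compound 1 `O=C(N/N=C/c1ccc2nonc2c1)c1cccnc1` at 209000 nM. Compound 3 `O=C(N/N=C/c1ccc2nonc2c1)c1ccncc1` reads > 400000 nM, which is a limit of the assay. The change from compound 2 to compound 4 `Cc1c(C(=O)N/N=C/c2ccc(Br)cc2)no[n+]1[O-]` is bromo in place of acetamido on an aromatic carbon, para to a large group. Going by the values given here, the one measured step, an at least 1.9-fold higher number from compound 1 to compound 3 (0.28 log units; that floor lies within the scatter), concerns a pyridinyl group on a carbonyl carbon, so it bears only loosely on this change. Among the compounds with values here, no measured step covers bromo or acetamido. No step beyond the scatter is therefore expected, in either direction. The expected shift is a 1.3-fold lower number from compound 2 to compound 4 (0.12 log units; within the scatter). For compound 4 the estimate is 180000 nM, with an expected range of 60000 nM to 400000 nM.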

Compound 4, half-maximal inhibitory concentration: 162000 nM
Compound 4: middle estimate off by 1.1-fold (0.05 log units), on the high side; the range from low to high includes it.
By their numbers in this assay, from the lowest: compounds 4, 1 and 2 (each within the scatter of the next). At a limit, above all of these: compound 3.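

In this assay, bromo in place of acetamido gives a 1.5-fold lower number from compound 2 to compound 4 (0.16 log units; within the scatter). On this aromatic carbon, para to a large group, going from 4 heavy atoms with a hydrogen-bond donor to 1 heavy atom without one therefore leaves the reading within the scatter. Both compounds give real numbers, so this step is not a floor like the earlier one, and only compound 3 stands at a limit: the limit of > 400000 nM in this assay, at which 1 of the 4 values shown sits.

As far as these compounds go, whether an amine or a carboxylic acid on this carbon would give a step beyond the scatter stays open. A single step at this position supports no trend across substituents.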